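The source may hold more compounds than are shown below. What is called first, only, known or untested is meant among the compounds shown, and "the series" means these compounds.

Measured so far in an ADME assay on a cell-free system (plasma, Rattus norvegicus) for protein binding:
- compound 1 `Cc1ccc(-c2cc(C(=O)N[C@H](C)c3ccc(C(F)(F)F)nc3)cc(C(C)(C)O)c2)nc1`: 95.2%
- compound 2 `Cc1ccc(-c2cc(C(=O)N[C@H](C)c3ccc(C(F)(F)F)[n+]([O-])c3)cc(C(C)(C)O)c2)nc1`: 62.4%

Of these two, compound 2 has the higher unbound fraction, at 62.4%. Compound 3 `C[C@@H](NC(=O)c1cc(-c2ccc(Cl)cc2)cc(C(C)(C)O)c1)c1ccc(C(F)(F)F)[n+]([O-])c1` keeps everything in compound 2 except one group: 4-chlorophenyl in place of 5-methylpyridin-2-yl on an aromatic carbon. Among the compounds with values here, this puts 4-chlorophenyl in place of 5-methylpyridin-2-yl on an aromatic carbon, and the hydrogen-bond acceptor of the leaving group has no counterpart in the entering one.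

Within the data shown here, only one measured step exists, a 7.8-fold higher unbound fraction from compound 1 to compound 2 (0.89 log units; beyond the scatter). Among the measured compounds shown here, it was made at a saturated chain carbon, so no measured step covers this swap directly, and it serves only as a rough guide to size. A smaller move in this assay is expected, toward less unbound compound.

The estimated step is a 2.1-fold lower unbound fraction from compound 2 to compound 3 (0.32 log units; beyond the scatter). For compound 3 the expected value is 82%, with an estimated range of 66% to 93%.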

Compound 3, plasma protein binding: 97.4%
Estimate against measurement, compound 3: 6.9-fold (0.84 log units) (unbound fraction) above; the whole stated range lies below it.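

At this aromatic carbon, meta to a 1-hydroxy-1-methylethyl group, binding in this assay depends strongly on the aryl group: 4-chlorophenyl in place of 5-methylpyridin-2-yl gives a 14-fold lower unbound fraction from compound 2 to compound 3 (1.16 log units; beyond the scatter). The change in a 7.8-fold higher unbound fraction from compound 1 to compound 2 (0.89 log units; beyond the scatter) therefore does not by itself secure a high unbound fraction, since compound 3 retains it and gives 97.4%. The swap exchanges a ring nitrogen and a methyl group for a chlorine and loses the hydrogen-bond acceptor of the leaving group, but nothing available explains the size of this step.

From the compounds shown here alone, it remains open whether the shift follows the loss of the ring nitrogen or the gain of the chlorine. Plain phenyl, 4-methylphenyl and 5-chloropyridin-2-yl at this position would separate the two.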